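A few compounds are considered here, and "the series" means these few. Any claim that something is new, unique, unknown or untested is made for them only; others in the source may bear on it.

Measured compounds:

compound 1 `CCCOC1=C(CCC)C(=O)/C(=C(O)/C=C/c2ccccc2)C(=O)C1(CCC)CCC` — 2.4 uM
compound 2 `CCCCC1=C(OC)C(CCCC)(CCCC)C(=O)/C(=C(O)\C=C\c2ccccc2)C1=O` — 8.6 uM
compound 3 `COC1=C(CC(C)C)C(=O)/C(=C(O)/C=C/c2ccccc2)C(=O)C1(CC(C)C)CC(C)C` — 8.2 uM

All three share one core and were tested in a functional assay on KBVIN cells (Homo sapiens) for antiproliferative activity, read by sulforhodamine B assay, with a stated time of 3 days; a lower number here means that less compound is needed, a higher number that more compound is needed for the effect. Compound 1 gives the lowest number of the three; compound 3 and compound 2 both need more compound for the same effect, and each of those gaps lies beyond the usual scatter of this assay, so compound 1 is the most potent of the three on these numbers. The three compounds differ from one another in several places at once, so no single change can be tied to any one of those gaps.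

Compound 4 `CCCCOC1=C(CCC)C(=O)/C(=C(O)/C=C/c2ccccc2)C(=O)C1(CCC)CCC` is a closer neighbour of compound 1. The only difference is methyl in place of hydrogen on a saturated chain carbon, three bonds along the chain from an oxygen on an unsaturated carbon; cut one bond further out, this reads as propyl to butyl on the oxygen-bearing chain. A change of this kind adds one carbon on a saturated chain and nothing else. In this assay compound 4 is therefore expected to land close to compound 1, with a step of a 1.3-fold higher number from compound 1 to compound 4 (0.10 log units; within the scatter) that stays within the usual scatter, leaning if anything toward a slightly higher number. The estimate for compound 4 is 3 uM, with a range from 1.2 uM to 7.5 uM.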

Compound 4, concentration for half-maximal effect: 8.9 uM
Beside the measured number, compound 4's estimate is 3.0-fold (0.47 log units) below it; the measured number lies above the stated range.
By their numbers in this assay, from the lowest: compound 1; then compounds 3, 2 and 4 (each within the scatter of the next).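

In this assay, within the data shown here, the change from propyl to butyl on the oxygen-bearing chain gives a 3.7-fold higher number from compound 1 to compound 4 (0.57 log units; beyond the scatter) and is the first difference here that can be tied to a single place in the structure. It shows that this position on the chain is sensitive: one added carbon, methyl in place of hydrogen on a saturated chain carbon, is enough to produce a step beyond the scatter. Nothing available here explains why this added carbon has this effect.

The compounds shown leave open whether a longer pentyl chain on the same oxygen would raise the number further, or whether a shorter ethyl chain there would lower it. They also leave open how a chain ending in an amine would behave at this position.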